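The source may report more compounds than this note shows. Statements on the series, on what has been measured and on what is new or still open speak of the compounds shown alone.

Measured so far in a functional assay on HUVEC cells (Homo sapiens) for inhibition, with stated times of 2 h and 72 h; a lower number here means a stronger inhibitor, a higher number a weaker inhibitor:
- compound 1 `COc1cc2nccc(Oc3ccc4c(NC(=O)c5cc(Cl)ccn5)nn(C)c4c3)c2cc1OC`: > 1000 nM, a limit
- compound 2 `COc1cc2nccc(Oc3ccc4c(NC(=O)c5cccc(C)c5)nn(C)c4c3)c2cc1OC`: > 1000 nM, a limit

Compound 2 has no number on this read-out, only the limit > 1000 nM. The measured set sits at a single limit: the limit of > 1000 nM in this assay, at which 2 of the 2 values shown sit.

Compound 3 `COc1ccc(NC(=O)Nc2nn(C)c3cc(Oc4ccnc5cc(OC)c(OC)cc45)ccc23)cc1` keeps the shared core and differs at one place: (4-methoxyphenyl)amino in place of 3-methylphenyl on a carbonyl carbon. In words, (4-methoxyphenyl)amino stands in place of 3-methylphenyl on a carbonyl carbon, so that ((3-methylphenyl)carbonyl)amino becomes ((4-methoxyphenyl)carbamoyl)amino.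

Among the measured compounds shown here, the only measured step, a step that the two limits leave unreadable from compound 1 to compound 2, also falls on a carbonyl carbon, but it has no readable size and gives no measure for this change. The expectation in this assay is therefore weakly founded. With compound 2 at > 1000 nM, a limit, only a step toward stronger inhibition could be read. The expected size is an at least 5.0-fold lower number from compound 2 to compound 3 (0.69 log units; beyond the scatter), toward stronger inhibition, and another limit reading remains quite possible.

For compound 3 the estimated value is 200 nM, with an expected range of 20 nM to 1000 nM.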

Compound 3, half-maximal inhibitory concentration: > 1000 nM
Compound 3: no number, only a limit; the forecaster's own chance of this, stated with the estimate: 30%; at least 5.0-fold (0.69 log units) between middle value and limit.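

In this assay, among the compounds shown here, compound 3 gives > 1000 nM as a limit, so no step among compound 1, compound 2 and compound 3 can be read. The series stays at one reading: the limit of > 1000 nM in this assay, at which 3 of the 3 values shown sit. The compounds shown leave open how strongly any of the three inhibits and whether the carbonyl-carbon changes alter that inhibition at all.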